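The source may hold more compounds than are shown below. What is called first, only, known or untested is meant among the compounds shown, and "the series" means these compounds.

Going by the values given here, in a functional assay on P388 cells (Mus musculus) for cytotoxicity (on this read-out lower numbers stand for stronger inhibition and higher numbers for weaker inhibition), compound 2 `CCN1C(=O)[C@@H](C)NC(=O)[C@@H]2Cc3ccc(OC)c(c3)Oc3ccc(cc3)C[C@@H](C(=O)N2C)N(C)C(=O)[C@H](C)NC(=O)[C@H](Cc2ccc(OC)cc2)N(C)C(=O)[C@@H]1C` gives 43.7 nM, the lower of the two numbers so far, while compound 1 `COc1ccc(C[C@H]2C(=O)N[C@@H](C)C(=O)N(C)[C@H]3Cc4ccc(cc4)Oc4cc(ccc4OC)C[C@@H](C(=O)N[C@H](C)C(=O)N[C@@H](CC(=O)O)C(=O)N2C)N(C)C3=O)cc1` gives 1200 nM, a gap beyond the usual scatter. Compound 3 `C=CCN1C(=O)[C@@H](C)NC(=O)[C@@H]2Cc3ccc(OC)c(c3)Oc3ccc(cc3)C[C@@H](C(=O)N2C)N(C)C(=O)[C@H](C)NC(=O)[C@H](Cc2ccc(OC)cc2)N(C)C(=O)[C@@H]1C` differs from compound 2 in one place: vinyl in place of methyl on a saturated chain carbon bound to an amide-type nitrogen in a ring. Put simply, an ethyl becomes an allyl. Among the compounds with values here, no measured pair shows this kind of change, so the forecast is uncertain. In this assay, a small shift towards a higher number is expected, probably not beyond the scatter. The expected step is a 1.4-fold higher number from compound 2 to compound 3 (0.14 log units; within the scatter). The estimated value for compound 3 is 60 nM, with an expected range from 20 nM to 180 nM.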

Compound 3, half-maximal inhibitory concentration: 18.6 nM
Compound 3: middle estimate off by 3.2-fold (0.51 log units), on the high side; measured number outside the range, below it.
By their numbers in this assay, from the lowest: compound 3; then compound 2; then compound 1.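

In this assay the change from ethyl to allyl gives a 2.3-fold lower number from compound 2 to compound 3 (0.37 log units; beyond the scatter) and so lies beyond the scatter, though the step is modest. At this place, a saturated chain carbon bound to an amide-type nitrogen in a ring, the added vinyl end with its double bond is therefore accepted without any loss of inhibition. Nothing available explains the gain.

The compounds shown leave open whether the double bond or simply the larger group matters, a question a propyl group could settle. As far as these compounds go, how an amine at the end of this chain would read also stays open.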